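From 4-chlorophenyl to 2-chloro-6-fluorophenyl

The source may report more compounds than this note shows. Statements on the series, on what has been measured and on what is new or still open speak of the compounds shown alone.

- compound 1 `Cc1cc(=O)c2c(O)cc(OCc3ccc([N+](=O)[O-])cc3)c([C@H]3CCN(C)C[C@H]3O)c2o1` gives 39%
- compound 2 `Cc1cc(=O)c2c(O)c(CN3CCN(C(=O)OC(C)(C)C)CC3)c(O)c([C@H]3CCN(C)C[C@H]3O)c2o1` gives 16%
- compound 3 `Cc1oc2c([C@H]3CCN(C)C[C@H]3O)c(O)cc(O)c2c(=O)c1C(O)c1ccc(Cl)cc1` gives 6%

All three were tested in a functional assay on MCF7 cells (Homo sapiens) for inhibition, read by MTT assay, with a stated time of 48 h, tested at 10 uM (a higher number here means more inhibition of growth at the concentration tested, a lower number less inhibition of growth), and share most of their structure. Compound 3 (6%) lies well under compound 1 (39%) and cannot be told apart from compound 2 (16%). The next compound is compound 4 `Cc1oc2c([C@H]3CCN(C)C[C@H]3O)c(O)cc(O)c2c(=O)c1C(O)c1c(F)cccc1Cl`, with 2-chloro-6-fluorophenyl in place of 4-chlorophenyl on a saturated chain carbon bound to an aromatic carbon and an oxygen on a saturated carbon. Going by the values given here, no measured pair differs in one place only, so the data offer no direct guide to this change. The expected change is small, within the scatter, and only slightly upward (a number 6 percentage points higher from compound 3 to compound 4 (within the scatter)). For compound 4 the estimated value in this assay is 12% (range 0% to 28%).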

Compound 4, percent growth inhibition at one concentration: 41%
Compound 4: the middle estimate sits 29 percentage points below what was measured; measured number above the stated range.
By their numbers in this assay, from the lowest: compounds 3 and 2 (each within the scatter of the next); then compounds 1 and 4 (each within the scatter of the next).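

In this assay replacing 4-chlorophenyl with 2-chloro-6-fluorophenyl on the saturated chain carbon gives a number 35 percentage points higher from compound 3 to compound 4 (beyond the scatter) and so shows that the result at this position depends strongly on what the aromatic ring carries. This is the first pair shown that differs in one place only, giving the first direct reading of a change here. Nothing measured here explains the rise.

The chlorine changes place and a fluorine enters in the same step, and the compounds shown do not separate these two changes. On these data alone, how a plain phenyl or a methoxyphenyl would behave at this position also remains open.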